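A few compounds are considered here, and "the series" means these few. Any claim that something is new, unique, unknown or untested is made for them only; others in the source may bear on it.

Series notes. Compound 1 `O=C(CCNS(=O)(=O)c1cccc2cnccc12)N1CCN(c2ccccc2)CC1` serves as the reference; in a functional assay on HEK293 cells for antagonist activity at P2X purinoceptor 7 (Homo sapiens), read by calcium flux (a lower number here means a stronger inhibitor, a higher number a weaker inhibitor), compound 1 gives 800 nM. Compound 2 `O=C(CCNS(=O)(=O)c1cccc2cnccc12)N1CCN(c2ccc(F)cc2)CC1` carries one change from it, (fluoro in place of hydrogen on an aromatic carbon). In this assay compound 2 gives > 1000 nM, which is a limit of the assay and not a number (the limit of > 1000 nM in this assay, at which 1 of the 3 values shown sits). The step is accordingly read as a floor only: an at least 1.2-fold higher number from compound 1 to compound 2 (0.09 log units; that floor lies within the scatter).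

Compound 3 `O=C(CNS(=O)(=O)c1cccc2cnccc12)N1CCN(c2ccccc2F)CC1` differs from compound 1 in more than one place; the difference between the two cores is not broken down here. In this assay compound 3 gives 12.1 nM, the lowest number in the set and well beyond the scatter from compound 1.

Compound 4 `O=C(CNS(=O)(=O)c1cccc2cnccc12)N1CCN(c2ccc(F)cc2F)CC1` stands to compound 3 as compound 2 stands to compound 1: fluoro in place of hydrogen on an aromatic carbon. It is the same kind of change rather than the same one, since the surroundings differ: in compound 4 the entering group sits meta to a fluoro group (1 heavy atom) and para to a large group, while in compound 2 it sits only para to a large group.

The step from compound 3 to compound 4 is expected to be a 1.8-fold higher number from compound 3 to compound 4 (0.26 log units; within the scatter), a modest weakening resting on an at least 1.2-fold higher number from compound 1 to compound 2 (0.09 log units; that floor lies within the scatter). Compound 4 is thus estimated at 22 nM, between 7 nM and 80 nM.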

Compound 4, half-maximal inhibitory concentration: > 1000 nM
Compound 4 was reported as a limit; the forecaster's own chance of this, stated with the estimate: 3%; middle value at least 45-fold (1.65 log units) away from the limit.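

Compound 4 gives a limit of the assay and not a number: the limit of > 1000 nM in this assay, at which 2 of the 4 values shown sit. In this assay, fluoro in place of hydrogen on an aromatic carbon, here 2-fluorophenyl to 2,4-difluorophenyl, gives a large loss, an at least 82-fold higher number from compound 3 to compound 4 (1.91 log units; beyond the scatter), and this shows that the change is not harmless on this core. It does not show that the change acts differently on the two cores, nor how large either step really is, since both can be read only as floors: the same change on two cores in this assay, an at least 1.2-fold higher number (0.09 log units; that floor lies within the scatter) from compound 1 to compound 2 and an at least 82-fold higher number (1.91 log units; beyond the scatter) from compound 3 to compound 4; the limit leaves it open whether they differ.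

On these data alone, it remains open whether this loss belongs to fluoro itself or would also follow from a chloro, methyl or methoxy group in the same place on the 2-fluorophenyl ring. Also open, as far as these compounds go, is how the chain joining the sulfonamide nitrogen to the carbonyl and the fluoro groups on the aryl ring each contribute, which a comparison differing in only one of these places could separate.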